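Moving the trifluoromethyl group from compound 2 to compound 3

A few compounds are considered here, and "the series" means these few. Any claim that something is new, unique, unknown or untested is made for them only; others in the source may bear on it.

Measured in a functional assay on DU-145 cells (Homo sapiens) for antiproliferative activity, read by propidium iodide staining, with a stated time of 96 h; on this read-out lower numbers stand for stronger inhibition and higher numbers for weaker inhibition:
- Compound 1 `CC(O)(CS(=O)(=O)c1ccc(F)cc1)C(=O)Nc1ccc(S(F)(F)(F)(F)F)cc1`: 27700 nM
- Compound 2 `CC(O)(CS(=O)(=O)c1ccc(C(F)(F)F)cc1)C(=O)Nc1ccc(S(F)(F)(F)(F)F)cc1`: 29300 nM

Among the compounds with values here, only two compounds have been measured so far, and they stand level. Within the data shown here, the single measured step is a 1.1-fold higher number from compound 1 to compound 2 (0.02 log units; within the scatter), so compound 2 cannot be told apart from compound 1 on these numbers.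

The next compound, compound 3 `CC(O)(CS(=O)(=O)c1ccccc1C(F)(F)F)C(=O)Nc1ccc(S(F)(F)(F)(F)F)cc1`, keeps the shared core of compound 2 and changes one group, with 2-(trifluoromethyl)phenyl in place of 4-(trifluoromethyl)phenyl on a sulfonyl sulfur. Both groups have the same atoms, joined differently.

The measured step bears on this change only indirectly. Among the measured compounds shown here, it exchanges fluoro for trifluoromethyl on an aromatic carbon, and no measured pair shows what moving the trifluoromethyl group does. The flat result of a 1.1-fold higher number from compound 1 to compound 2 (0.02 log units; within the scatter) gives no reason to expect a large effect, but it is thin evidence.

The expected step is a 1.1-fold lower number from compound 2 to compound 3 (0.04 log units; within the scatter), which means no estimated change beyond the scatter in this assay, in either direction. For compound 3 the estimated value is 27000 nM, with an expected range from 11000 nM to 55000 nM.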

Compound 3, half-maximal inhibitory concentration: 29400 nM
Estimate against measurement, compound 3: 1.1-fold (0.04 log units) below; measured number inside the range.
By their numbers in this assay, from the lowest: compounds 1, 2 and 3 (each within the scatter of the next).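

In this assay, within the data shown here, 2-(trifluoromethyl)phenyl in place of 4-(trifluoromethyl)phenyl on the sulfonyl sulfur gives a 1.0-fold higher number from compound 2 to compound 3 (0.00 log units; within the scatter), the first direct look at moving the trifluoromethyl group, and on these numbers the move cannot be told from no change. Set against 4-fluorophenyl, the same 2-(trifluoromethyl)phenyl group gives a 1.1-fold higher number from compound 1 to compound 3 (0.03 log units; within the scatter), so changing the group and its place together also leaves the number level, and all three aryl groups on the sulfonyl sulfur stand within the scatter of one another in this read-out. No supporting evidence is available that bears on why these numbers stay level.

The compounds shown leave open whether this flat response would hold for an aryl group carrying an amine or a carboxylic acid, or for a sulfonyl sulfur bearing a saturated chain in place of an aromatic ring. From the compounds shown here alone, every change seen so far sits on the aryl group of the sulfonyl sulfur, so what a change elsewhere on the shared core would do in this assay remains unknown.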